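This account rests on a few compounds, and the source may have more. Where it says the series, first, only, none or still open, it means among the compounds named here.

Measured compounds:
compound 1 `CC(C)(C)N(NC(=O)c1ccccc1)C(=O)c1ccccc1F` — 309 nM
compound 2 `CC(C)(C)N(NC(=O)c1ccccc1)C(=O)c1ccccc1Br` — 170 nM
compound 3 `CC(C)(C)N(NC(=O)c1ccccc1Cl)C(=O)c1ccccc1Cl` — 331 nM

All three values come from an assay on cells for agonist activity at ecdysone receptor (Bombyx mori), read by a luciferase reporter, with a stated time of 24 h; on this read-out higher numbers stand for an effect only at larger amounts of compound and lower numbers for an effect already at smaller amounts. Compound 3 carries the highest of the three numbers, but its gap to compound 1 and its gap to compound 2 are each within the scatter, so the three compounds stand together on this read-out.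

Compound 4 `CC(C)(C)N(NC(=O)c1ccc(I)cc1)C(=O)c1ccccc1Cl` differs from compound 3 by 4-iodophenyl in place of 2-chlorophenyl on a carbonyl carbon. For the measured compounds named here, the only step between measured compounds is a 1.8-fold lower number from compound 1 to compound 2 (0.26 log units; within the scatter), a halogen swap on the other carbonyl-bound ring, and it did not leave the scatter. Compound 1 and compound 3, which differ at both rings, give values within the scatter of each other. Going by the values given here, no measured pair speaks to a 4-iodophenyl, nor to a change at the carbonyl carbon next to the amide-type nitrogen.

Halogen changes seen so far have moved the numbers little, so no step beyond the scatter is expected from compound 3 to compound 4, estimated as a 1.2-fold lower number from compound 3 to compound 4 (0.07 log units; within the scatter). Compound 4 is therefore estimated at 280 nM, with a range from 90 nM to 900 nM.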

Compound 4, half-maximal effective concentration: 7.59 nM
Beside the measured number, compound 4's estimate is 37-fold (1.57 log units) above it, outside the stated range (below it).
By their numbers in this assay, from the lowest: compound 4; then compounds 2, 1 and 3 (each within the scatter of the next).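

In this assay, for the compounds shown here, the change of group on a carbonyl carbon whose other neighbours are amide-type nitrogen gives the first step beyond the scatter (a 44-fold lower number from compound 3 to compound 4 (1.64 log units; beyond the scatter)). The halogen swap on the other carbonyl-bound ring stayed within the scatter (a 1.8-fold lower number from compound 1 to compound 2 (0.26 log units; within the scatter)), so the read-out is not insensitive to halogen-bearing aryl changes across the whole series, and the group on this carbonyl carbon can move it strongly. Nothing available explains the size of this step.

The step changes the halogen and its place on the ring together, and the compounds shown include neither 4-chlorophenyl nor 2-iodophenyl at this carbonyl carbon to separate the two. Also open, going by these compounds, is whether 4-bromophenyl, 4-methoxyphenyl or 4-aminophenyl would keep the low number seen with 4-iodophenyl.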